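This account rests on a few compounds, and the source may have more. Where it says the series, first, only, none or still open, it means among the compounds named here.

In a functional assay on HUVEC cells (Homo sapiens) for inhibition, read by ELISA and BrdU incorporation (a lower number here means a stronger inhibitor, a higher number a weaker inhibitor), compound 1 `Cc1cc(Cl)cc(C(=O)Nc2cnc3ccccc3c2)c1` gives 560 nM and compound 2 `Cc1cc(Br)cc(C(=O)Nc2cnc3ccccc3c2)c1O` gives 470 nM, two numbers within the scatter of each other. Compound 3 `Cc1cc(Br)cc(C(=O)Nc2cnc3ccccc3c2)c1` differs from compound 2 at one place: hydrogen in place of hydroxy on an aromatic carbon, ortho to a methyl group and para to a bromo group (hydrogen in place of hydroxy on an aromatic carbon). Going by the values given here, no measured pair shows this change alone, so there is no step to draw on, and no shift beyond the scatter is expected in this assay. The expected change is a 1.1-fold higher number from compound 2 to compound 3 (0.03 log units; within the scatter). For compound 3 the estimated value is 500 nM, with a range of 200 nM to 1300 nM.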

Compound 3, half-maximal inhibitory concentration: 720 nM
The estimate for compound 3 lay 1.4-fold (0.16 log units) below the measured number; the range from low to high includes it.
By their numbers in this assay, from the lowest: compounds 2, 1 and 3 (each within the scatter of the next).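

In this assay hydrogen in place of hydroxy gives a 1.5-fold higher number from compound 2 to compound 3 (0.19 log units; within the scatter) and so, at this place ortho to a methyl group and para to a bromo group, the two groups cannot be told apart. Bromo in place of chloro gives a 1.3-fold higher number from compound 1 to compound 3 (0.11 log units; within the scatter) and is equally unresolved, so neither single change has a clear effect on the number here. As far as these compounds go, whether a methoxy group, an amine or a carboxylic acid at the hydroxy place would move the number beyond the scatter remains open. No available data explain either step.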